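The compounds below may be only part of what the source reports. "The series", "measured", "known", "first", "only" and "open" are said of these compounds alone.

Measured compounds in a functional assay on ASPC1 cells (Homo sapiens) for inhibition, read by MTT assay, with a stated time of 72 h; a lower number here means a stronger inhibitor of growth, a higher number a weaker inhibitor of growth:

compound 1, `O=S(=O)(NCCCNCc1ccc(Cl)c(C(F)(F)F)c1)c1cc(C(F)(F)F)cc(C(F)(F)F)c1`, gives 9600 nM
compound 2, `O=S(=O)(NCCCNCc1ccc(C(F)(F)F)cc1)c1cc(C(F)(F)F)cc(C(F)(F)F)c1`, gives 2000 nM
compound 3, `O=S(=O)(NCCCNCc1ccccc1)c1cc(C(F)(F)F)cc(C(F)(F)F)c1`, gives 13000 nM

Compound 3 stands highest of the three numbers. Its nearest neighbour is compound 1, and the step of a 1.4-fold higher number from compound 1 to compound 3 (0.13 log units; within the scatter) lies within the scatter, so the two cannot be ordered. Its furthest neighbour is compound 2: the step of a 6.5-fold higher number from compound 2 to compound 3 (0.81 log units; beyond the scatter) is modest but beyond the scatter.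

Compound 4, `O=S(=O)(NCCCNCc1ccc(-c2ccccc2)cc1)c1cc(C(F)(F)F)cc(C(F)(F)F)c1`, differs from compound 3 in one place: phenyl in place of hydrogen on an aromatic carbon. Of the measured steps, the one that bears most directly on this change is a 6.5-fold higher number from compound 2 to compound 3 (0.81 log units; beyond the scatter), since it concerns the same aromatic carbon, where removing a trifluoromethyl left a higher number. The step of a 4.8-fold lower number from compound 1 to compound 2 (0.68 log units; beyond the scatter) shows that the pattern of substitution on this ring moves the number by a modest amount in either direction. Among the compounds with values here, no measured step shows a phenyl entering at this position, so the size of the step is uncertain.

The expectation is therefore a modest lowering of the number, estimated as a 3.3-fold lower number from compound 3 to compound 4 (0.51 log units; beyond the scatter). Compound 4 is estimated to give 4000 nM in this assay, with a range from 1000 nM to 15000 nM.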

Compound 4, concentration for 50% growth inhibition: 2500 nM
Compound 4: middle estimate off by 1.6-fold (0.20 log units), on the high side; the measured number falls inside the stated range.
By their numbers in this assay, from the lowest: compounds 2 and 4 (each within the scatter of the next); then compounds 1 and 3 (each within the scatter of the next).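

In this assay, a phenyl on the aromatic carbon para to a large group gives a 5.2-fold lower number from compound 3 to compound 4 (0.72 log units; beyond the scatter), which shows that this position accepts a whole added aromatic ring of carbon only and that the number still falls. The step of a 1.3-fold higher number from compound 2 to compound 4 (0.10 log units; within the scatter) lies within the scatter, so phenyl and trifluoromethyl cannot be ordered at this place, and two quite different groups on this carbon each leave compound 3 behind by a step beyond the scatter; compound 1, which also carries a group on this carbon, goes against that pattern, with a 1.4-fold higher number from compound 1 to compound 3 (0.13 log units; within the scatter) lying within the scatter. Nothing given here explains why these groups behave alike at this position.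

The compounds shown leave open whether the lower number depends on an aromatic ring at all, since a cyclohexyl, a methoxy or a carboxylic acid on the same carbon would separate that question from simple substitution. They also leave open how a nitrogen within the added ring, as in a pyridine, or a substituent on the outer phenyl would move the number.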